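Trimming the side chain: from compound 2 to compound 4

The source may hold more compounds than are shown below. What is called first, only, known or untested is meant among the compounds shown, and "the series" means these compounds.

Measured so far in a functional assay on PC-3 cells (Homo sapiens) for cytotoxicity, read by MTT assay, with a stated time of 72 h; a higher number here means a weaker inhibitor, a lower number a stronger inhibitor:
- compound 1 `CCCOCNc1n[n+]([O-])c2cc(OC)ccc2[n+]1[O-]`: 10600 nM
- compound 2 `COc1ccc2c(c1)[n+]([O-])nc(NCOC(C)c1ccccc1)[n+]2[O-]`: > 100000 nM
- compound 3 `COCNc1n[n+]([O-])c2ccccc2[n+]1[O-]`: 4270 nM

Compound 2 stands at the weak end of the set. Its value in this assay is a limit of the assay, not a number, at the limit of > 100000 nM in this assay, at which 1 of the 3 values shown sits. Compound 1 and compound 3 both give numbers, and compound 1 sits within the region where a number is returned.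

Compound 4 `COc1ccc2c(c1)[n+]([O-])nc(NCOCc1ccccc1)[n+]2[O-]` is still to be measured. It differs from compound 2 by hydrogen in place of methyl on a saturated chain carbon bound to an aromatic carbon and an oxygen on a saturated carbon.

Going by the values given here, the one measured step that bears on this change is an at least 9.4-fold higher number from compound 1 to compound 2 (0.97 log units; beyond the scatter), where the larger group at the same oxygen was accompanied by a loss of potency. Compound 4 keeps the phenyl but drops the methyl, so a partial move back toward compound 1 is expected, though nothing measured fixes how far.

Compound 4 is therefore expected at 40000 nM, within 8000 nM to 200000 nM. The expected step is an at least 2.5-fold lower number from compound 2 to compound 4 (0.39 log units; beyond the scatter).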

Compound 4, half-maximal inhibitory concentration: 88500 nM
For compound 4 the middle estimate is 2.2-fold (0.34 log units) below the measured one, and the stated range covers the measured number.
By their numbers in this assay, from the lowest: compound 3; then compound 1; then compound 4. At a limit, above all of these: compound 2.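

Compound 2 stays a limit of the assay, not a number: the limit of > 100000 nM in this assay, at which 1 of the 4 values shown sits. The step reads as an at least 1.1-fold lower number from compound 2 to compound 4 (0.05 log units; that floor lies within the scatter), so the data do not show that losing the methyl on this saturated chain carbon changes anything beyond the scatter. The new information is a true size for the change at this oxygen in this assay, where the earlier step gave only a floor: an 8.3-fold higher number from compound 1 to compound 4 (0.92 log units; beyond the scatter), and with the methyl gone this loss goes with phenyl in place of ethyl on the chain.

The compounds shown leave open whether that loss belongs to the aromatic ring itself or to the added carbons, which a cyclohexyl or a longer chain such as hexyl at the same place would separate. On these data alone, how an amine or a carboxylic acid on the phenyl would shift the number also remains open.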